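Working notes: amino for chloro, compound 2 to compound 3

The compounds below may be only part of what the source reports. "The series", "measured", "known", "first", "only" and "open" are said of these compounds alone.

Compound 1 `Clc1ncnc2c1ncn2Cc1ccccc1` gives 0% in an assay on isolated protein for inhibition of RAC-alpha serine/threonine-protein kinase (Homo sapiens), tested at 30 uM; a higher number here means more inhibition at the concentration tested (going by the name of the read-out), a lower number less inhibition. Among the compounds with values here, compound 2 `Fc1ccc(Cn2cnc3c(Cl)ncnc32)cc1`, with a fluoro in place of hydrogen on an aromatic carbon, gives 0% in this assay; the one measured step is no change at the digits printed from compound 1 to compound 2 (within the scatter). Compound 2 thus stands level with compound 1 at the digits shown, and neither measured compound shows inhibition beyond the scatter.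

Compound 3 `Nc1ncnc2c1ncn2Cc1ccc(F)cc1` differs from compound 2 by amino in place of chloro on an aromatic carbon. Within the data shown here, no measured step concerns this position or this exchange of groups; the single step on record, no change at the digits printed from compound 1 to compound 2 (within the scatter), concerns the fluoro elsewhere on the structure and left the read-out unchanged, so it offers no guide for amino in place of chloro. With both measured compounds showing no inhibition and nothing in the set pointing to a shift from this change, no step beyond the scatter is expected; the estimated step is a number 3 percentage points higher from compound 2 to compound 3 (within the scatter). Compound 3 is estimated at 3%, with an expected range from -10% to 20%.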

Compound 3, a percentage reported as inhibition, at one concentration (the size of the read-out at that concentration, not a potency): 0%
Estimate against measurement, compound 3: 3 percentage points above; measured number inside the range.
By their numbers in this assay, from the lowest: compounds 1, 2 and 3 (each within the scatter of the next).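

The second measured exchange, this time on the aromatic carbon next to the ring nitrogen, also leaves the read-out in place: amino in place of chloro gives no change at the digits printed from compound 2 to compound 3 (within the scatter) in this assay. So the chloro is not needed for the read-out to stay where it stands, and a hydrogen-bond donor and a hydrogen-bond acceptor entering at this position, with the amino, do not lift it beyond the scatter. No independent measurement is available to interpret this flat result.

Within the data shown here, since compound 1, compound 2 and compound 3 all sit at the same value, the series so far has no measured inhibition against which the effect of any change could be gauged, and the exchange at this position cannot be ranked. Open, on these data alone, is whether a larger group here, such as a piperazine, a morpholine or a longer chain ending in an amine, or a carboxylic acid in place of the fluoro, would move the read-out beyond the scatter.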